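A new group on sulfur in compound 3

The compounds below may be only part of what the source reports. "The series", "measured", "known", "first", "only" and "open" are said of these compounds alone.

Compound 1 `O=C(CSc1ncccn1)N/N=c1/scc(-c2ccc(Br)cc2)n1-c1ccccc1` - > 200 ug/mL (a limit, not a number)
Compound 2 `Cn1nnnc1SCC(=O)N/N=c1/scc(-c2ccc(Cl)cc2)n1-c1ccccc1` - "not determined" (no result reported)

These entries come from a functional assay on C6 cells (Rattus norvegicus) for cytotoxicity, read by MTT assay, with a stated time of 24 h; a higher number here means a weaker inhibitor, a lower number a stronger inhibitor. Compound 2 has no single number there: its entry reads "not determined" (no result reported), so it cannot be ranked against anything. Compound 1 holds the only other result, and that result is a limit: the limit of > 200 ug/mL in this assay, at which 1 of the 2 values shown sits. Compound 3 `O=C(CSc1ncccn1)N/N=c1/scc(-c2ccc(Cl)cc2)n1-c1ccccc1` has yet to be measured. The step pyrimidin-2-yl in place of 1-methyl-1H-tetrazol-5-yl on a sulfur puts pyrimidin-2-yl in place of 1-methyl-1H-tetrazol-5-yl on a sulfur. Going by the values given here, with no number for compound 2, the size of this step cannot be read from the data, and the only guide is compound 1 at > 200 ug/mL, which is a limit. Compound 3 is therefore expected to be a weak inhibitor in this assay, with no step beyond the usual scatter from that limit. The estimated value for compound 3 is 150 ug/mL, with an expected range from 30 ug/mL to 400 ug/mL.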

Compound 3, half-maximal inhibitory concentration: 83.3 ug/mL
Beside the measured number, compound 3's estimate is 1.8-fold (0.26 log units) above it; the range from low to high includes it.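

Going by these compounds alone, with the (pyrimidin-2-yl)sulfanyl group held fixed, this assay now shows that the aromatic halogen matters: chloro in place of bromo on an aromatic carbon gives an at least 2.4-fold lower number from compound 1 to compound 3 (0.38 log units; beyond the scatter) and brings the series to a measured number for the first time. Going by these compounds, the true size of this step stays unknown because compound 1 stands at a limit and not at a number: the limit of > 200 ug/mL in this assay, at which 1 of the 3 values shown sits. The step at the sulfur itself, pyrimidin-2-yl in place of 1-methyl-1H-tetrazol-5-yl, cannot be read, as compound 2 has no result.

On these data alone, whether fluoro or methoxy in place of chloro would carry the change further remains open. So does how a phenyl group or an aminoethyl chain on the sulfur would compare with pyrimidin-2-yl.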